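The source may hold more compounds than are shown below. What is called first, only, known or untested is meant among the compounds shown, and "the series" means these compounds.

Compound 1 `O=C(O)CC(CC1CCN(C(=O)CCc2ccc3c(n2)NCCC3)CC1)c1cccc(F)c1` was examined in an in vivo ADME assay on the whole organism (Rattus norvegicus) for pharmacokinetics, at pH 2 (a lower number here means that a smaller share of the oral dose reaches the circulation, a higher number that a larger share of the oral dose reaches the circulation), where compound 1 gives 14%. Within the data shown here, of the two numbers in hand this is the higher one: its closest neighbour is compound 2 `COc1ncc(C(CC(=O)O)CC2CCN(C(=O)CCc3ccc4c(n3)NCCC4)CC2)c(OC)n1`, which in this assay gives 1%, so that the step of a number 13 percentage points lower from compound 1 to compound 2 (beyond the scatter) is the only measured change on record. The unmeasured compound 3 `O=C(O)CC(CC1CCN(C(=O)CCc2ccc3c(n2)NCCC3)CC1)c1ccc2ccccc2c1` differs from compound 1 in one place: naphthalen-2-yl in place of 3-fluorophenyl on a saturated chain carbon bound to two saturated chain carbons. Among the measured compounds shown here, no measured step covers this exchange; the step from compound 1 to compound 2 concerns a different replacement at the same place and serves only to show that a change at this carbon can move the read-out beyond the scatter. On this footing compound 3 is expected to stay close to compound 1, with the estimated step of a number 2 percentage points lower from compound 1 to compound 3 (within the scatter) lying within the scatter. The estimated value for compound 3 is therefore 12%, within a range from 2% to 30%.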

Compound 3, oral bioavailability: 47%
Estimate against measurement, compound 3: 35 percentage points below, outside the stated range (above it).
By their numbers in this assay, from the lowest: compound 2; then compound 1; then compound 3.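

In this assay, the carbon with the aryl group, a saturated chain carbon bound to two saturated chain carbons, proves able to raise the read-out as well as lower it: naphthalen-2-yl in place of 3-fluorophenyl gives a number 33 percentage points higher from compound 1 to compound 3 (beyond the scatter). Against the 2,4-dimethoxypyrimidin-5-yl group, the same naphthalen-2-yl gives a number 46 percentage points higher from compound 2 to compound 3 (beyond the scatter), so the three groups at this one place span a wide range on an otherwise shared core. Nothing at hand gives a measured property that would account for this rise.

The compounds shown leave open whether the higher number goes with the second aromatic ring of naphthalen-2-yl or with the absence of fluorine, a question that a plain phenyl group at this carbon would address. They also leave open whether naphthalen-1-yl would behave like naphthalen-2-yl.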